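Swapping the Bromophenyl for a Nitrophenyl on the Thioether Arm

The source may report more compounds than this note shows. Statements on the series, on what has been measured and on what is new or still open speak of the compounds shown alone.

Measured compounds:
Compound 1 `OC[C@H]1O[C@@H](n2cnc3c(SCc4cccc(Cl)c4)ncnc32)[C@H](O)[C@@H]1O`: 18.2 nM
Compound 2 `OC[C@H]1O[C@@H](n2cnc3c(SCc4ccc(Br)cc4)ncnc32)[C@H](O)[C@@H]1O`: 11.5 nM
Compound 3 `N#Cc1cccc(CSc2ncnc3c2ncn3[C@@H]2O[C@H](CO)[C@@H](O)[C@H]2O)c1`: 36.3 nM

All three compounds share the same core and differ only in the aryl group that sits on a saturated chain carbon bound to a sulfur. In an assay on isolated protein for inhibition of Equilibrative nucleoside transporter 1 (Homo sapiens) (a lower number here means a stronger inhibitor, a higher number a weaker inhibitor), compound 2 stands at the low end of the three: the step of a 1.6-fold lower number from compound 1 to compound 2 (0.20 log units; within the scatter) lies within the usual scatter, so compound 1 and compound 2 cannot be told apart, whereas the step of a 3.2-fold higher number from compound 2 to compound 3 (0.50 log units; beyond the scatter) lies beyond it.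

Compound 4 `O=[N+]([O-])c1ccccc1CSc1ncnc2c1ncn2[C@@H]1O[C@H](CO)[C@@H](O)[C@H]1O` is not yet measured. Its change from compound 2 is 2-nitrophenyl in place of 4-bromophenyl on a saturated chain carbon bound to a sulfur. Within the data shown here, two measured steps bear on this: a 1.6-fold lower number from compound 1 to compound 2 (0.20 log units; within the scatter) and a 3.2-fold higher number from compound 2 to compound 3 (0.50 log units; beyond the scatter), both of which also exchange the aryl group in that place. The first stayed within the scatter; the second, which brought in a cyano-bearing ring, gave a modest weakening. The nitro group, like the cyano group, adds hydrogen-bond acceptors, so a modest weakening is expected for compound 4 in this assay, of about a 3.5-fold higher number from compound 2 to compound 4 (0.54 log units; beyond the scatter). The estimate for compound 4 is therefore 40 nM, with a range from 15 nM to 120 nM.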

Compound 4, inhibition constant: 115 nM
Estimate against measurement, compound 4: 2.9-fold (0.46 log units) below; measured number inside the range.
By their numbers in this assay, from the lowest: compounds 2, 1 and 3 (each within the scatter of the next, the first and the last beyond it); then compound 4.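

In this assay the aryl group on a saturated chain carbon bound to a sulfur turns out to be able to cost much more than the earlier exchanges showed, with a 10-fold higher number from compound 2 to compound 4 (1.00 log units; beyond the scatter) and with a 6.3-fold higher number from compound 1 to compound 4 (0.80 log units; beyond the scatter) as well. Compound 4 is the weakest inhibitor of the four, and even the exchange of the 3-cyanophenyl group for the 2-nitrophenyl group gives a 3.2-fold higher number from compound 3 to compound 4 (0.50 log units; beyond the scatter) so a ring carrying a nitrogen-containing substituent does not by itself predict the result at this place. Nothing available here accounts for this loss.

The 2-nitrophenyl group differs from the other three aryl groups both in its substituent and in where that substituent stands on the ring, so these compounds cannot separate the effect of the nitro group from the effect of its placement. A 4-nitrophenyl group would allow a direct comparison with the 4-bromophenyl group of compound 2, while rings carrying an amine or a carboxylic acid would show how far this place tolerates other kinds of substituent.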